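The source may report more compounds than this note shows. Statements on the series, on what has been measured and on what is new or still open speak of the compounds shown alone.

Three compounds built on a shared core are compared in a functional assay on PC-3 cells (Homo sapiens) for antiproliferative activity, read by MTT assay, with a stated time of 72 h; on this read-out lower numbers stand for stronger inhibition and higher numbers for weaker inhibition. Compound 1 `O=C(N/N=C/c1ccc(Br)cc1)Nc1ccc(Oc2ccnc3[nH]ccc23)cc1` carries a bromine on the six-membered aromatic ring of carbon only, and in this assay compound 1 is reported as "not active" (no number reported). Compound 2 `O=C(N/N=C/c1ccc([N+](=O)[O-])cc1)Nc1ccc(Oc2ccnc3[nH]ccc23)cc1` carries a nitro group at that place instead, and in this assay compound 2 gives 28100 nM. Going by the values given here, compound 2 therefore stands as the only compound with a number; the one further entry carries no number at all. Compound 3 `COc1ccc(/C=N/NC(=O)Nc2ccc(Oc3ccnc4[nH]ccc34)cc2)cc1` is the next compound to be tested, and it differs from compound 2 in one place: methoxy in place of nitro on an aromatic carbon. Among the compounds with values here, no pair of measured compounds differing in a single place is available, so there is no measured step to lean on. Within the data shown here, compound 2 gives only weak inhibition at 28100 nM and compound 1 shows "not active" (no number reported), so weak inhibition is the common picture for this series so far. For compound 3 the expected step is a 1.6-fold higher number from compound 2 to compound 3 (0.20 log units; within the scatter), toward weaker inhibition, with a real chance that only a limit is reported. Compound 3 is expected to give 45000 nM, with a likely range from 12000 nM to 200000 nM.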

Compound 3, half-maximal inhibitory concentration: "not active" (no number reported)
No number was reported for compound 3; the estimate stays without a comparison.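

Going by these compounds alone, compound 3, like compound 1, is reported without a number, so no step from compound 2 to compound 3 can be read. The compounds shown leave open how the group on the six-membered aromatic ring relates to inhibition, with compound 2 the only one carrying a number. Nothing measured here accounts for this result.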